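The source may report more compounds than this note shows. Statements on the series, on what has been measured and on what is new or still open speak of the compounds shown alone.

In an ADME assay on microsomes from liver (Rattus norvegicus) for metabolic stability (on this read-out lower numbers stand for a shorter-lived compound and higher numbers for a longer-lived compound), compound 3 (`Nc1nc(NCCNc2ncc(-c3ncc[nH]3)c(-c3ccc(F)cc3F)n2)ccc1[N+](=O)[O-]`) gives > 0.5 h, a limit and not a number. Compound 1 (`FC(F)(F)c1ccc(NCCNc2ncc(-c3ncc[nH]3)c(-c3ccc(Cl)cc3Cl)n2)nc1`) gives > 0.5 h, also a limit. Compound 2 (`Clc1ccc(-c2nc(NCCNc3ccccn3)ncc2-c2ncc[nH]2)c(Cl)c1`) gives > 0.5 h, again a limit. Compound 4 (`Nc1nc(NCCNc2ncc(-c3ncc[nH]3)c(-c3ccc(F)cc3C(F)(F)F)n2)ccc1[N+](=O)[O-]`) carries trifluoromethyl in place of fluoro on an aromatic carbon, ortho to a large group: trifluoromethyl in place of fluoro on an aromatic carbon. Among the measured compounds shown here, only one measured step involves trifluoromethyl, a step that the two limits leave unreadable from compound 1 to compound 2, and it offers no size to carry over. The whole record comes down to the limit of > 0.5 h in this assay, at which 3 of the 3 values shown sit. With compound 3 held at the limit > 0.5 h, no step beyond the scatter is expected in this assay. The expected change is a step that the limit leaves unreadable from compound 3 to compound 4. Compound 4 is estimated at 0.6 h, with an expected range of 0.3 h to 1.2 h.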

Compound 4, half-life: > 0.5 h
Compound 4 gave a limit, no number (the forecaster's own chance of this, stated with the estimate: 75%); the middle value is on the limit's open side.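

Compound 3 and compound 4 both give only a limit, and no step can be read between them. In this assay the compounds shown leave open the actual half-life of each, and whether trifluoromethyl in place of fluoro changes it.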